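This account rests on a few compounds, and the source may have more. Where it says the series, first, only, none or still open, it means among the compounds named here.

Measured so far:
compound 1 `Clc1cccc(-c2cc(-c3ccc(Cl)o3)cc(-c3cccs3)n2)c1`: 19800 nM
compound 2 `Cc1ccc(-c2cc(-c3ccoc3)cc(-c3ccsc3)n2)cc1`: 47800 nM
compound 3 `Clc1cccc(-c2cc(-c3ccc(Cl)o3)cc(-c3ccsc3)n2)c1`: 23000 nM

All three numbers come from a functional assay on K562 cells (Homo sapiens) for cytotoxicity, in the presence of a further agent that is not named here; on this read-out higher numbers stand for weaker inhibition and lower numbers for stronger inhibition. Compound 1 gives the lowest of the three numbers, but compound 3 sits within the usual scatter of it, so the two cannot be ranked; the step of a 1.2-fold higher number from compound 1 to compound 3 (0.07 log units; within the scatter) shows this. Compound 2 stands furthest away, with a higher number than compound 1 that does lie beyond the scatter.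

Compound 4 `Cc1ccc(-c2cc(-c3ccc(Cl)o3)cc(-c3cccs3)n2)cc1` has not been measured. It differs from compound 1 in one place: 4-methylphenyl in place of 3-chlorophenyl on an aromatic carbon.

Among the measured compounds shown here, no measured pair differs by this change alone, so no step bears on it directly. Compound 2 also carries a 4-methylphenyl group, yet it differs from compound 1 and compound 3 in two further places, so its higher number cannot be assigned to that group. For the measured compounds named here, the only single step known, from compound 1 to compound 3, concerns a different ring and stayed within the scatter.

Compound 4 is therefore expected to give a number near that of compound 1, with a lean toward a higher number in this assay, an estimated step of a 1.5-fold higher number from compound 1 to compound 4 (0.18 log units; within the scatter). The estimate for compound 4 is 30000 nM, with a range from 12000 nM to 75000 nM.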

Compound 4, half-maximal inhibitory concentration: 21500 nM
Compound 4: the middle estimate sits 1.4-fold (0.14 log units) above what was measured; the measured number falls inside the stated range.
By their numbers in this assay, from the lowest: compounds 1, 4 and 3 (each within the scatter of the next); then compound 2.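

In this assay, placing 4-methylphenyl where compound 1 carries 3-chlorophenyl, on the aromatic carbon next to the ring nitrogen, gives a 1.1-fold higher number from compound 1 to compound 4 (0.04 log units; within the scatter), so compound 1 and compound 4 cannot be ranked. At this position, then, a chlorine on one ring carbon and a methyl on another read alike, even though the substituent and its place on the phenyl ring both differ; both groups have 7 heavy atoms and neither has a hydrogen-bond donor or acceptor. Nothing shown here explains this likeness.

Going by these compounds, what stays open is how far this position accepts other groups, such as a phenyl ring carrying an amine or a carboxylic acid, or a longer chain in place of the ring. On these data alone, it is also open whether the same exchange would read alike with thiophen-3-yl in the place of thiophen-2-yl.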